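This account rests on a few compounds, and the source may have more. Where it says the series, first, only, none or still open, it means among the compounds named here.

Three compounds share one core and differ only in the ester-bearing side chain. Compound 1 is `Nc1ncnc2c1ncn2CC(O)C(=O)OCCO`, compound 2 is `COCCOC(=O)C(O)Cn1cnc2c(N)ncnc21`, and compound 3 is `CCCCCOC(=O)C(O)Cn1cnc2c(N)ncnc21`. In a functional assay on HeLa cells (Homo sapiens) for cytotoxicity (on this read-out lower numbers stand for higher toxicity in this test and higher numbers for lower toxicity in this test), compound 1 gives > 400 ug/mL, which is a limit of the assay and not a number. In this assay compound 2 gives > 400 ug/mL, again a limit. In this assay compound 3 gives > 400 ug/mL, also a limit. Compound 2 therefore stands exactly where the others stand: the limit of > 400 ug/mL in this assay, at which 3 of the 3 values shown sit.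

The step that the two limits leave unreadable from compound 1 to compound 2, the step that the two limits leave unreadable from compound 1 to compound 3 and the step that the two limits leave unreadable from compound 2 to compound 3 each run between two limits, so their size cannot be read.

Compound 4 is `CCCOC(=O)C(O)Cn1cnc2c(N)ncnc21`. It differs from compound 2 in one place: methyl in place of methoxy on a saturated chain carbon, two bonds along the chain from an oxygen next to a carbonyl group. The measured steps bear on this change only in that every alteration on a saturated chain carbon, two bonds along the chain from an oxygen next to a carbonyl group, left the read-out at the limit. No step beyond the scatter is therefore expected in this assay, in either direction. Compound 4 is expected to give 800 ug/mL, within 300 ug/mL to 3000 ug/mL. The step that the limit leaves unreadable from compound 2 to compound 4 is expected to stay within the scatter, and most likely the assay again reports only its limit.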

Compound 4, minimum cytotoxic concentration: > 400 ug/mL
Compound 4 gave a limit, no number (the forecaster's own chance of this, stated with the estimate: 90%); the middle value does not contradict the limit.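

In this assay, for the compounds shown here, compound 4 sits at a limit, as do compound 1, compound 2 and compound 3, so no step between compound 4 and any of them can be read. As far as these compounds go, whether these ester side chains differ in toxicity at all remains open; none of the four compounds gives a number.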